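Replacing (vinylcarbonyl)oxy with (methylsulfonyl)methyl: compound 4

A few compounds are considered here, and "the series" means these few. Any claim that something is new, unique, unknown or untested is made for them only; others in the source may bear on it.

In a functional assay on A-375 cells (Homo sapiens) for cytotoxicity, read by MTT assay (a higher number here means a weaker inhibitor, a lower number a stronger inhibitor), compound 1 (`COc1ccc(/C=C/C(=O)c2ccc(OC)c3c2OC(C)(C)C=C3)cc1OCCO`) gives 9600 nM, compound 2 (`CCC(=O)Oc1cc(/C=C/C(=O)c2ccc(OC)c3c2OC(C)(C)C=C3)ccc1OC`) gives 240 nM and compound 3 (`C=CC(=O)Oc1cc(/C=C/C(=O)c2ccc(OC)c3c2OC(C)(C)C=C3)ccc1OC`) gives 390 nM. Compound 3 therefore belongs to the low pair of the three numbers. The gap within that pair is small, a 1.6-fold higher number from compound 2 to compound 3 (0.21 log units; within the scatter). The steps away from 2-hydroxyethyl are large: a 40-fold lower number from compound 1 to compound 2 (1.60 log units; beyond the scatter) and a 25-fold lower number from compound 1 to compound 3 (1.39 log units; beyond the scatter).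

Compound 4 (`COc1ccc(/C=C/C(=O)c2ccc(OC)c3c2OC(C)(C)C=C3)cc1CS(C)(=O)=O`) carries (methylsulfonyl)methyl in place of (vinylcarbonyl)oxy on an aromatic carbon. Within the data shown here, no measured step covers this exchange. Among the measured compounds shown here, the only guide is compound 1 at 9600 nM, which shows that a compound without the acyl group can lie much higher. A moderate rise is expected, a 3.8-fold higher number from compound 3 to compound 4 (0.59 log units; beyond the scatter). Compound 4 is estimated at 1500 nM, within 350 nM to 7000 nM.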

Compound 4, half-maximal inhibitory concentration: > 10000 nM
Compound 4 was reported as a limit; the forecaster's own chance of this, stated with the estimate: 5%; middle value at least 6.6-fold (0.82 log units) away from the limit.
By their numbers in this assay, from the lowest: compounds 2 and 3 (each within the scatter of the next); then compound 1. At a limit, above all of these: compound 4.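

Compound 4 stands only as a limit in this assay: the limit of > 10000 nM in this assay, at which 1 of the 4 values shown sits.

At this aromatic carbon, matching counts of heavy atoms and hydrogen-bond acceptors do not preserve the low numbers of the acyloxy compounds: an at least 25-fold higher number from compound 3 to compound 4 (1.40 log units; beyond the scatter) and an at least 41-fold higher number from compound 2 to compound 4 (1.61 log units; beyond the scatter). Against the 2-hydroxyethoxy compound, the limit gives no readable order: an at least 1.0-fold higher number from compound 1 to compound 4 (0.01 log units; that floor lies within the scatter).

On these data alone, it remains open whether the ester oxygen or the acyl carbonyl matters more here. A methylsulfonyloxy group, an acetamide or a butanoyloxy chain at this carbon would address that question.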